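Methoxy count against growth inhibition in one series

The source may hold more compounds than are shown below. What is called first, only, known or untested is meant among the compounds shown, and "the series" means these compounds.

Values in a functional assay on NCI-H23 cells (Homo sapiens) for inhibition, read by sulforhodamine B assay, with a stated time of 48 h; a higher number here means a weaker inhibitor of growth, a lower number a stronger inhibitor of growth:
compound 1 `COc1cc(-c2cc(/C=C/C(=O)c3ccc(N)cc3)[nH]n2)cc(OC)c1OC`: 6790 nM
compound 2 `COc1ccc(C(=O)/C=C/c2cc(-c3cc(OC)c(OC)c(OC)c3)n[nH]2)cc1OC`: 5240 nM
compound 3 `COc1ccc(-c2cc(/C=C/C(=O)c3ccc(N)cc3)[nH]n2)cc1OC`: 19300 nM

Compound 2 carries the lowest number of the three, but the step of a 1.3-fold lower number from compound 1 to compound 2 (0.11 log units; within the scatter) lies within the scatter, so compound 1 and compound 2 are not separated by this assay. Among the compounds with values here, the one change that does register is a 2.8-fold lower number from compound 3 to compound 1 (0.45 log units; beyond the scatter), where the structures differ by methoxy in place of hydrogen on an aromatic carbon. How the core of compound 2 differs from the core of compound 3 is not broken down here.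

Compound 4 `COc1cc(C(=O)/C=C/c2cc(-c3cc(OC)c(OC)c(OC)c3)n[nH]2)cc(OC)c1OC` is not yet measured. It differs from compound 2 by methoxy in place of hydrogen on an aromatic carbon, and the surroundings of the place are the same word for word as in the step from compound 3 to compound 1, so this is the same change made a second time. Within the data shown here, the expected step is a 2.5-fold lower number from compound 2 to compound 4 (0.40 log units; beyond the scatter), resting on a 2.8-fold lower number from compound 3 to compound 1 (0.45 log units; beyond the scatter) as the only precedent. With a single precedent the range is kept wide. Compound 4 is estimated at 2100 nM in this assay, between 800 nM and 5500 nM.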

Compound 4, concentration for total growth inhibition: 9900 nM
Beside the measured number, compound 4's estimate is 4.7-fold (0.67 log units) below it, and the stated range ends below it.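

In this assay, methoxy in place of hydrogen on an aromatic carbon does not carry over as one fixed step from one core to the other: the same change on two cores in this assay, a 2.8-fold lower number (0.45 log units; beyond the scatter) from compound 3 to compound 1 and a 1.9-fold higher number (0.28 log units; within the scatter) from compound 2 to compound 4, 5.4-fold (0.73 log units) apart, beyond the scatter of two such steps. Taken alone, a 1.9-fold higher number from compound 2 to compound 4 (0.28 log units; within the scatter) does not separate the two compounds, so on this core the added methoxy shows neither a gain nor a loss in growth inhibition. The result shows that the step from one core is a poor guide to the other in this series, but with one pair per core it does not show why the two steps differ or how the same change would read on a third core.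

Still open, on these data alone, is whether a different group at the same place on the core of compound 2, such as ethoxy, hydroxy or fluorine, would give a step beyond the scatter. Also open, as far as these compounds go, is whether an amine in place of one of the methoxy groups on that ring would change the reading.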